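Swapping a pyridinyloxy group for a pyridone ring

The source may report more compounds than this note shows. Statements on the series, on what has been measured and on what is new or still open speak of the compounds shown alone.

Measured compounds:
compound 1 `Cc1cc(N2CCCC2)c(S(C)(=O)=O)cc1C(=O)N=C(N)N` — 11 nM
compound 2 `Cc1cc(-n2ccnc2C)c(S(C)(=O)=O)cc1C(=O)N=C(N)N` — 29 nM
compound 3 `Cc1cc(Oc2cccnc2)c(S(C)(=O)=O)cc1C(=O)N=C(N)N` — 8.8 nM

These three compounds share one core and differ only in the group placed on one aromatic carbon. In a functional assay for inhibition of sodium/hydrogen exchanger (Oryctolagus cuniculus) (a higher number here means a weaker inhibitor, a lower number a stronger inhibitor), compound 3 gives 8.8 nM, the lowest of the three numbers; one of the two steps that lead to it is small (a 1.3-fold lower number from compound 1 to compound 3 (0.10 log units; within the scatter)), whereas the other is clear (a 3.3-fold lower number from compound 2 to compound 3 (0.52 log units; beyond the scatter)). So the pyrrolidinyl and pyridinyloxy groups behave alike, and the ring joined through its nitrogen atom, 2-methyl-1H-imidazol-1-yl, does modestly worse.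

Compound 4 `Cc1cc(-n2ccc(=O)cc2)c(S(C)(=O)=O)cc1C(=O)N=C(N)N` carries a group of 7 heavy atoms (5 carbon, 1 nitrogen, 1 oxygen; one six-membered aromatic ring with 1 hetero atom) in place of a group of 7 heavy atoms (5 carbon, 1 nitrogen, 1 oxygen; one six-membered aromatic ring with 1 hetero atom), on an aromatic carbon. The new group, like that of compound 2, is a heterocycle joined to the core through its nitrogen atom, so the step of a 3.3-fold lower number from compound 2 to compound 3 (0.52 log units; beyond the scatter) is the closest guide, tempered by the unchanged step a 1.3-fold lower number from compound 1 to compound 3 (0.10 log units; within the scatter). A modest rise in the number, or none beyond the scatter, is therefore expected, with a 2.0-fold higher number from compound 3 to compound 4 (0.31 log units; beyond the scatter). Compound 4 is estimated at 18 nM in this assay, within a range from 7 nM to 50 nM.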

Compound 4, half-maximal inhibitory concentration: 75 nM
The estimate for compound 4 lay 4.2-fold (0.62 log units) below the measured number, outside the stated range (above it).
By their numbers in this assay, from the lowest: compounds 3 and 1 (each within the scatter of the next); then compound 2; then compound 4.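

In this assay, rearranging the same atoms at this position, with (pyridin-3-yl)oxy giving way to a pyridone ring joined through its nitrogen atom, produces an 8.5-fold higher number from compound 3 to compound 4 (0.93 log units; beyond the scatter), so the counts of atoms, hydrogen-bond donors and hydrogen-bond acceptors do not settle the outcome here. Being joined through nitrogen does not settle it either: the pyridone ring gives a 2.6-fold higher number from compound 2 to compound 4 (0.41 log units; beyond the scatter) and also a 6.8-fold higher number from compound 1 to compound 4 (0.83 log units; beyond the scatter), and so sits clearly above both of the other nitrogen-joined groups, the 2-methyl-1H-imidazol-1-yl ring and the pyrrolidin-1-yl ring. Nothing measured here gives a reason for these rises.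

Going by these compounds, it remains open whether the oxygen link of compound 3 or the carbonyl of compound 4 matters more. A plain phenoxy group or a piperidin-1-yl group at this position would help to separate the two.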